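Swapping 3-methoxybenzyl for 4-methoxyphenyl on the shared core

This account rests on a few compounds, and the source may have more. Where it says the series, first, only, none or still open, it means among the compounds named here.

Compound 1 `Cc1ccccc1Nc1nc(Nc2cccnc2)ncc1Cl`: 38600 nM
Compound 2 `Cc1ccccc1Nc1nc(NCc2ccncc2)ncc1Cl`: > 100000 nM, which is a limit of the assay rather than a number
Compound 3 `COc1cccc(CNc2nc(Nc3ccc(N4CCN(C)CC4)cn3)ncc2Cl)c1`: 73400 nM

All three compounds were tested in a functional assay on Jurkat cells (Homo sapiens) for inhibition, read by CCK-8 assay, with a stated time of 48 h; on this read-out higher numbers stand for weaker inhibition of growth and lower numbers for stronger inhibition of growth. Among the two numbers, compound 3 has the higher one, but its gap to compound 1 is within the scatter, so the two cannot be told apart. Compound 2 gave only a limit, as noted in the limit of > 100000 nM in this assay, at which 1 of the 3 values shown sits.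

Compound 4 `COc1ccc(Nc2nc(Nc3ccc(N4CCN(C)CC4)cn3)ncc2Cl)cc1` has not been measured. It differs from compound 3 by 4-methoxyphenyl in place of 3-methoxybenzyl on a nitrogen on an aromatic ring. Going by the values given here, the one measured step that resembles this change runs the other way: an at least 2.5-fold higher number from compound 1 to compound 2 (0.41 log units; beyond the scatter), where a ring attached directly to the nitrogen was replaced by a ring held off it by one carbon, and inhibition weakened. Compound 4 makes the reverse move, a ring directly on the nitrogen in place of a benzyl group, so a lower number is expected for compound 4, estimated as a 2.9-fold lower number from compound 3 to compound 4 (0.47 log units; beyond the scatter). Compound 4 is therefore expected to give about 25000 nM in this assay, between 8000 nM and 80000 nM.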

Compound 4, concentration for 50% growth inhibition: 11200 nM
Beside the measured number, compound 4's estimate is 2.2-fold (0.35 log units) above it; measured number inside the range.
By their numbers in this assay, from the lowest: compound 4; then compounds 1 and 3 (each within the scatter of the next). At a limit, above all of these: compound 2.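

In this assay this change gives a 6.6-fold lower number from compound 3 to compound 4 (0.82 log units; beyond the scatter), a step with a measured number at both ends. The earlier step ended at compound 2, whose value is a limit, and it altered the pyridine-carrying group, whereas this step alters the group carrying the methoxy. In these two pairs alone, then, a ring set directly on the nitrogen goes with the lower number at both of these places on the shared core.

The change also moves the methoxy group, so this step cannot divide its effect between losing the one-carbon link and moving the methoxy; 3-methoxyphenyl or 4-methoxybenzyl on this nitrogen would separate the two. Nothing shown accounts for the size of this step.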